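The source may report more compounds than this note shows. Statements on the series, on what has been measured and on what is new or still open speak of the compounds shown alone.

Measured so far in a functional assay on B16-F10 cells (Mus musculus) for cytotoxicity, read by CCK-8 assay, with a stated time of 48 h; on this read-out lower numbers stand for stronger inhibition and higher numbers for weaker inhibition:
compound 1 `NS(=O)(=O)c1ccc(/N=C/c2c(Cl)c3ccccc3oc2=O)cc1` gives 300 nM
compound 2 `N=C(N)NS(=O)(=O)c1ccc(/N=C/c2c(Cl)c3ccccc3oc2=O)cc1` gives 180 nM
compound 3 `Cc1cc(NS(=O)(=O)c2ccc(/N=C/c3c(Cl)c4ccccc4oc3=O)cc2)no1` gives 270 nM

All three share one core and differ only in what sits on the sulfonamide nitrogen. Compound 3 has the second highest of the three numbers, yet every gap around it is small: a 1.1-fold lower number from compound 1 to compound 3 (0.05 log units; within the scatter) and a 1.5-fold higher number from compound 2 to compound 3 (0.18 log units; within the scatter) both fall within the scatter, as does a 1.7-fold lower number from compound 1 to compound 2 (0.22 log units; within the scatter). Compound 4 `Cc1ccnc(NS(=O)(=O)c2ccc(/N=C/c3c(Cl)c4ccccc4oc3=O)cc2)n1` carries 4-methylpyrimidin-2-yl in place of 5-methyl-1,2-oxazol-3-yl on a sulfonamide nitrogen. The measured steps that bear on this change all concern the same nitrogen: a hydrogen, a small acyclic group and a five-membered aromatic ring there gave numbers that cannot be told apart. Nothing among these compounds suggests that a different aromatic ring on that nitrogen would move the number beyond the scatter, so the step of no change at the digits printed from compound 3 to compound 4 (within the scatter) is expected to be small and in no firm direction. Compound 4 is therefore estimated to give about 270 nM, most likely between 130 nM and 560 nM.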

Compound 4, half-maximal inhibitory concentration: 230 nM
For compound 4 the middle estimate is 1.2-fold (0.07 log units) above the measured one, and the stated range covers the measured number.
By their numbers in this assay, from the lowest: compounds 2, 4, 3 and 1 (each within the scatter of the next).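

In this assay, the six-membered 4-methylpyrimidin-2-yl can stand in place of the five-membered 5-methyl-1,2-oxazol-3-yl on the sulfonamide nitrogen with a 1.2-fold lower number from compound 3 to compound 4 (0.07 log units; within the scatter) and no readable effect, so this swap of ring size leaves the number unresolved from the earlier ones. The new ring also matches the other two compounds: a 1.3-fold higher number from compound 2 to compound 4 (0.11 log units; within the scatter) and a 1.3-fold lower number from compound 1 to compound 4 (0.12 log units; within the scatter) are both within the scatter, so all four groups on this nitrogen, hydrogen included, cannot be told apart. Nothing available here offers an explanation for this flat picture.

Still open, going by these compounds, is whether a different kind of group on this nitrogen, such as a carboxylic acid or a longer alkyl chain, would move the number beyond the scatter. On these data alone, it is also open whether an amine in place of the chlorine on the shared core would do so.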